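Branched alkyl for furan-2-yl at the ring carbon

The compounds below may be only part of what the source reports. "The series", "measured", "known", "first", "only" and "open" are said of these compounds alone.

Measured so far:
compound 1 `CCCn1c(=O)c2nc(C(C)(O)CC)[nH]c2n(CCC)c1=O` — 240 nM
compound 2 `CCCn1c(=O)c2nc(-c3ccco3)[nH]c2n(CCC)c1=O` — 560 nM

In an assay on cell membranes for binding affinity to adenosine receptor A1 (Cavia porcellus), read by radioligand binding (on this read-out lower numbers stand for stronger inhibition and higher numbers for weaker inhibition), compound 2 holds the higher of the two numbers; its nearest neighbour is compound 1, and the step of a 2.3-fold higher number from compound 1 to compound 2 (0.37 log units; beyond the scatter) places compound 2 as the weaker binder of the pair. Compound 3 `CCCn1c(=O)c2nc(C(C)(C)CCC)[nH]c2n(CCC)c1=O` differs from compound 2 by 1,1-dimethylbutyl in place of furan-2-yl on an aromatic carbon. Among the compounds with values here, the one measured step that bears on this change is a 2.3-fold higher number from compound 1 to compound 2 (0.37 log units; beyond the scatter), in which 1-hydroxy-1-methylpropyl gave way to furan-2-yl and the number rose modestly. Compound 3 exchanges the furan-2-yl for a branched alkyl group once more, but the hydroxyl present in compound 1 is absent here, so a return towards the number of compound 1 is only partly supported. A modest downward step a 2.5-fold lower number from compound 2 to compound 3 (0.41 log units; beyond the scatter) is therefore expected, with the size uncertain. For compound 3 the expected value in this assay is 220 nM, with a range from 70 nM to 700 nM.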

Compound 3, inhibition constant: 25 nM
The estimate for compound 3 lay 8.8-fold (0.94 log units) above the measured number, and the stated range ends above it.
By their numbers in this assay, from the lowest: compound 3; then compound 1; then compound 2.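

In this assay, the substituent on this aromatic carbon between two ring nitrogen atoms can move the number much further than the first pair suggested: a 22-fold lower number from compound 2 to compound 3 (1.35 log units; beyond the scatter) is a large step, and 1,1-dimethylbutyl gives the lowest number of the three. The branched alkyl group also outdoes the hydroxylated branched group, with a 9.6-fold lower number from compound 1 to compound 3 (0.98 log units; beyond the scatter), so compound 3 does not simply return to the level of compound 1, and neither a furan-2-yl ring nor a hydroxyl is needed for a low number at this place. Nothing at hand explains either step.

The step from compound 1 to compound 3 changes both the hydroxyl and the chain, so the two remain inseparable; 1,1-dimethylpropyl, with a methyl in place of the hydroxyl, would separate them. Also open, going by these compounds, is how a cyclohexyl or phenyl ring, a longer branched chain, or a chain ending in an amine or a carboxylic acid would read at this place.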